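The compounds below may be only part of what the source reports. "The series", "measured", "known", "first", "only" and "open" are said of these compounds alone.

Measured compounds: compound 1 `C=CCn1c(=O)/c(=C\c2ccc(Cl)c(Cl)c2)[nH]c(=O)/c1=C\c1ccccc1OC`, "not active" (no number reported) in a functional assay on K562 cells (Homo sapiens) for cytotoxicity, read by CCK-8 assay, with a stated time of 72 h; on this read-out higher numbers stand for weaker inhibition and lower numbers for stronger inhibition; compound 2 `C=CCn1c(=O)/c(=C\c2cc(Br)ccc2F)[nH]c(=O)/c1=C\c1ccccc1OC`, 5100 nM; compound 3 `C=CCn1c(=O)/c(=C\c2ccccc2OC)[nH]c(=O)/c1=C\c1ccccc1OC`, 7400 nM.

Among the compounds with values here, compound 3 and compound 2 carry the only two numbers; the step of a 1.5-fold higher number from compound 2 to compound 3 (0.16 log units; within the scatter) places them within the scatter of each other, so neither stands apart. Compound 1, which carries two chlorines on its aryl, gave no number at all.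

Compound 4 `C=CCn1c(=O)/c(=C\c2ccc(F)c(Br)c2)[nH]c(=O)/c1=C\c1ccccc1OC` differs from compound 3 by 3-bromo-4-fluorophenyl in place of 2-methoxyphenyl on a double-bonded chain carbon bound to an aromatic carbon. Within the data shown here, only one measured step bears on such an exchange of aryl, a 1.5-fold higher number from compound 2 to compound 3 (0.16 log units; within the scatter), and it lay within the scatter. Compound 1 cautions that a dihalogenated aryl may give no number. The step of a 1.1-fold higher number from compound 3 to compound 4 (0.03 log units; within the scatter) is therefore expected to be small, with the risk of no number. Compound 4 is estimated at 8000 nM, range 3000 nM to 25000 nM.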

Compound 4, half-maximal inhibitory concentration: "not active" (no number reported)
Compound 4: no number reported; the estimate stays without a comparison.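

Within the data shown here, compound 4 gives "not active" (no number reported) and no new step against compound 3 can be read. Nothing shown bears on this result. The compounds shown leave open why compound 1 and compound 4 give no number while compound 2, also dihalogenated on its aryl, gives one.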